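The compounds below may be only part of what the source reports. "The series", "measured", "known", "first", "only" and "open" are said of these compounds alone.

Among the compounds with values here, compound 2 `CC(C)N1CCC(Oc2ccc(C(=O)Nc3ccc(NC(=O)Nc4cc(C(C)(C)C)on4)cc3)nc2)CC1` gives 17.5% in an in vivo ADME assay on the whole organism (plasma, strain Sprague-Dawley) for pharmacokinetics, with Rattus norvegicus as the target, read by LC-MS, at a dose of 10 mg/kg by the oral route (on this read-out lower numbers stand for lower oral bioavailability and higher numbers for higher oral bioavailability), the larger of the two values measured so far, though the gap to compound 1 is within the scatter. Compound 1 `CC1(C)CC(Oc2ccc(C(=O)Nc3ccc(NC(=O)Nc4cc(C(C)(C)C)on4)cc3)nc2)CC(C)(C)N1` gives 8% in this assay. Within the data shown here, the only step seen so far, a number 9.5 percentage points higher from compound 1 to compound 2 (within the scatter), changes the group on the ring nitrogen and stays within the scatter. Compound 3 `CC(C)(C)c1cc(NC(=O)Nc2ccc(NC(=O)c3ccc(OC4CCN(C(C)(C)C)CC4)cn3)cc2)no1` differs from compound 2 by methyl in place of hydrogen on a saturated chain carbon bound to an amine nitrogen in a ring and two saturated chain carbons, again on that ring nitrogen group. Since a number 9.5 percentage points higher from compound 1 to compound 2 (within the scatter) showed no movement beyond the scatter, no step beyond it is expected here. Compound 3 is therefore estimated at 17%, between 8% and 30%, which would mean a number 0.5 percentage points lower from compound 2 to compound 3 (within the scatter).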

Compound 3, oral bioavailability: 22%
Compound 3: middle estimate off by 5 percentage points, on the low side, within the range that was stated.
By their numbers in this assay, from the lowest: compounds 1, 2 and 3 (each within the scatter of the next, the first and the last beyond it).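

On the ring nitrogen, going from isopropyl to tert-butyl adds one methyl and gives a number 4.5 percentage points higher from compound 2 to compound 3 (within the scatter) in this assay so this extra carbon brings no change that can be told from the scatter. Comparing 1-(tert-butyl)piperidin-4-yl with 2,2,6,6-tetramethylpiperidin-4-yl on the oxygen gives a number 14 percentage points higher from compound 1 to compound 3 (beyond the scatter) and this is the first step here that clears the scatter, though only modestly. No supporting measurement bears on the reason for either step.

As far as these compounds go, how a cyclopropyl group or a plain hydrogen on that ring nitrogen would compare remains open.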